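A Pyrazinyl Carbonyl Replaces Cyclobutyl on the Shared Core

The source may report more compounds than this note shows. Statements on the series, on what has been measured and on what is new or still open speak of the compounds shown alone.

Compound 3 `CCCCNc1nc(N)nc2c1CN(C(=O)C1CCC1)CC2` was tested in an assay on HEK293 cells for agonist activity at Toll-like receptor 8 (Homo sapiens), read by a luciferase reporter, with a stated time of 6 h (a higher number here means that more compound is needed for the effect, a lower number that less compound is needed), where compound 3 gives 0.4 uM. Among the three measured compounds it holds the second highest number: its nearest neighbour is compound 1 `CCCCNc1nc(N)nc2c1CN(C(C)=O)CC2`, for which compound 1 gives 0.5 uM, and its furthest is compound 2 `CCCCNc1nc(N)nc2c1CN(Cc1ccccc1Cl)CC2`, for which compound 2 gives 0.05 uM. Compound 4 `CCCCNc1nc(N)nc2c1CN(C(=O)c1cnccn1)CC2` has not yet been measured. It differs from compound 3 in one place: pyrazin-2-yl in place of cyclobutyl on a carbonyl carbon. The step that bears most directly on this change is a 1.3-fold lower number from compound 1 to compound 3 (0.10 log units; within the scatter), a change on the same carbonyl carbon that stayed within the scatter. The larger steps, a 10-fold lower number from compound 1 to compound 2 (1.00 log units; beyond the scatter) and an 8.0-fold higher number from compound 2 to compound 3 (0.90 log units; beyond the scatter), changed the group on the amine nitrogen in a ring rather than on the carbonyl carbon, and they speak less directly to compound 4. Among the compounds with values here, the one comparable change, a 1.3-fold lower number from compound 1 to compound 3 (0.10 log units; within the scatter), moved little, and a step of a 1.3-fold higher number from compound 3 to compound 4 (0.10 log units; within the scatter) is therefore expected, within or near the scatter. Compound 4 is estimated at 0.5 uM, with a range from 0.15 uM to 1.5 uM.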

Compound 4, minimum effective concentration: 2.2 uM
The estimate for compound 4 lay 4.4-fold (0.64 log units) below the measured number; measured number above the stated range.
By their numbers in this assay, from the lowest: compound 2; then compounds 3 and 1 (each within the scatter of the next); then compound 4.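

Methyl and cyclobutyl on the carbonyl carbon had stayed within the scatter of each other, yet in this assay pyrazin-2-yl gives a 5.5-fold higher number from compound 3 to compound 4 (0.74 log units; beyond the scatter) and also a 4.4-fold higher number from compound 1 to compound 4 (0.64 log units; beyond the scatter) at this same place. The carbonyl carbon, which had seemed indifferent to its substituent, therefore does respond to the group it carries, at least when that group is this six-membered aromatic ring with two hetero atoms. Against the 2-chlorobenzyl on the amine nitrogen in a ring, the (pyrazin-2-yl)carbonyl gives a 44-fold higher number from compound 2 to compound 4 (1.64 log units; beyond the scatter) as the largest step in the set. Nothing available explains why the number rises with pyrazin-2-yl. On these data alone, whether phenyl on the same carbonyl carbon would stay with cyclobutyl and methyl or follow pyrazin-2-yl remains open, so the ring itself and its two nitrogens cannot yet be told apart.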